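The compounds below may be only part of what the source reports. "The series", "measured", "known", "first", "only" and "open" are said of these compounds alone.

Measured compounds:
- compound 1 `O=C1N=C(O)S/C1=C\c1ccc(OCCc2ccsc2)cc1`: in an assay for inhibition of 15-hydroxyprostaglandin dehydrogenase [NAD(+)] (Homo sapiens), read by fluorescence and spectrophotometry (a higher number here means a weaker inhibitor, a lower number a stronger inhibitor), compound 1 gives 60 nM
- compound 2 `O=C1N=C(O)S/C1=C\c1ccc(OCc2cccs2)cc1`: compound 2 gives 287 nM
- compound 3 `Cc1ccc(COc2ccc(/C=C3\SC(O)=NC3=O)cc2)cc1`: compound 3 gives 232 nM

Compound 3 stands second highest of the three numbers; its nearest neighbour is compound 2, with a 1.2-fold lower number from compound 2 to compound 3 (0.09 log units; within the scatter), while the widest gap is a 3.9-fold higher number from compound 1 to compound 3 (0.59 log units; beyond the scatter).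

Compound 4 `CC1CCC(COc2ccc(/C=C3\SC(O)=NC3=O)cc2)CC1` is not yet measured. The change from compound 3 is 4-methylcyclohexyl in place of 4-methylphenyl on a saturated chain carbon bound to an oxygen on an aromatic ring. Going by the values given here, no measured step swaps an aromatic ring for a saturated one at this position, so the bearing of earlier steps is indirect. The two steps that touch the same place, a 4.8-fold higher number from compound 1 to compound 2 (0.68 log units; beyond the scatter) and a 3.9-fold higher number from compound 1 to compound 3 (0.59 log units; beyond the scatter), were modest, and a 1.2-fold lower number from compound 2 to compound 3 (0.09 log units; within the scatter) lay within the scatter, so changes of the group at this place have so far moved this assay by small to modest amounts. A step of similar size or none beyond the scatter is expected in this assay, with no firm direction; the estimate for compound 4 means a 1.3-fold higher number from compound 3 to compound 4 (0.11 log units; within the scatter). Compound 4 is expected near 300 nM, within 100 nM to 900 nM.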

Compound 4, half-maximal inhibitory concentration: 52 nM
Estimate against measurement, compound 4: 5.8-fold (0.76 log units) above; measured number outside the range, below it.
By their numbers in this assay, from the lowest: compounds 4 and 1 (each within the scatter of the next); then compounds 3 and 2 (each within the scatter of the next).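

In this assay, 4-methylcyclohexyl in place of 4-methylphenyl gives a 4.5-fold lower number from compound 3 to compound 4 (0.65 log units; beyond the scatter), so at this place an aromatic ring is not needed and, with the same count of heavy atoms, a saturated ring gives the lower number; the step from the thiophen-2-yl group is of similar size, a 5.5-fold lower number from compound 2 to compound 4 (0.74 log units; beyond the scatter). The change also reaches the range of the (thiophen-3-yl)methyl group, with a 1.2-fold lower number from compound 1 to compound 4 (0.06 log units; within the scatter) within the scatter, so two quite different groups at this place give values that cannot be told apart. Nothing measured here accounts for the gain from the saturated ring.

Going by these compounds, whether the gain comes from the saturated ring alone or needs its 4-methyl group remains open, as an unsubstituted cyclohexyl would show. Also open, on these data alone, is how a longer chain carrying the cyclohexyl ring, or an amine or a carboxylic acid on that ring, would behave.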